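A small halogen swap on the outer phenyl ring

The compounds below may be only part of what the source reports. "The series", "measured", "known", "first", "only" and "open" are said of these compounds alone.

Three compounds share one core and differ only in the group carried on the outer phenyl ring. Compound 1 `Cc1cccc(-n2cc(-c3cccc(NS(=O)(=O)c4c[nH]c(=O)[nH]c4=O)c3)nn2)c1` and compound 2 `Cc1ccc(-n2cc(-c3cccc(NS(=O)(=O)c4c[nH]c(=O)[nH]c4=O)c3)nn2)cc1` carry a methyl there; compound 3 `O=c1[nH]cc(S(=O)(=O)Nc2cccc(-c3cn(-c4cccc(F)c4)nn3)c2)c(=O)[nH]1` carries a fluoro. In a functional assay on A549 cells (Homo sapiens) for antiproliferative activity, read by MTT assay, with a stated time of 24 h (on this read-out higher numbers stand for weaker inhibition and lower numbers for stronger inhibition), compound 1 gives 3550 nM, compound 2 gives 3630 nM, and compound 3 gives 7200 nM. Within the data shown here, compound 3 therefore holds the highest of the three numbers, though only the step of a 2.0-fold higher number from compound 1 to compound 3 (0.31 log units; beyond the scatter) lies beyond the scatter, while the steps of a 1.0-fold higher number from compound 1 to compound 2 (0.01 log units; within the scatter) and a 2.0-fold higher number from compound 2 to compound 3 (0.30 log units; within the scatter) do not.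

Compound 4 `O=c1[nH]cc(S(=O)(=O)Nc2cccc(-c3cn(-c4cccc(Cl)c4)nn3)c2)c(=O)[nH]1` is the next member: chloro in place of fluoro on an aromatic carbon, placed on an aromatic carbon of a six-membered aromatic ring of carbon only, meta to a large group. Among the measured compounds shown here, no measured pair isolates this fluoro-to-chloro exchange, so the nearest guide is how little the ring substituent has mattered so far: the largest move, a 2.0-fold higher number from compound 1 to compound 3 (0.31 log units; beyond the scatter), was modest, and the other two stayed inside the scatter. The expectation is therefore a step of a 1.3-fold lower number from compound 3 to compound 4 (0.12 log units; within the scatter) in this assay, not clearly beyond the scatter, with a slight lean toward a lower number. Compound 4 is accordingly estimated at 5500 nM, with a likely range from 2700 nM to 11000 nM.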

Compound 4, half-maximal inhibitory concentration: 2430 nM
Compound 4: the middle estimate sits 2.3-fold (0.35 log units) above what was measured; the whole stated range lies above it.
By their numbers in this assay, from the lowest: compounds 4, 1, 2 and 3 (each within the scatter of the next, the first and the last beyond it).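

In this assay, the exchange of 3-fluorophenyl for 3-chlorophenyl gives a 3.0-fold lower number from compound 3 to compound 4 (0.47 log units; beyond the scatter), so this position on the outer ring responds to a change between two halogens, and the step lies beyond the scatter. Set against the methyl compounds, the steps of a 1.5-fold lower number from compound 1 to compound 4 (0.16 log units; within the scatter) and a 1.5-fold lower number from compound 2 to compound 4 (0.17 log units; within the scatter) both stay within the scatter, so chloro and methyl on this ring cannot be told apart here, and the fluoro of compound 3 is separated from compound 1 and compound 4 but not from compound 2. Nothing available explains why the two halogens differ at this position.

As far as these compounds go, it remains open whether bromo, methoxy, trifluoromethyl or an amine on this same carbon would extend the change or fall within the range of the compounds so far. From the compounds shown here alone, it is also open whether chloro on another carbon of the ring would give a number close to that of compound 4, and whether the gap between chloro and fluoro would persist there.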